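The source may report more compounds than this note shows. Statements on the series, on what has been measured and on what is new or still open speak of the compounds shown alone.

In a functional assay on MCF7 cells (Homo sapiens) for inhibition, read by MTT assay, with a stated time of 4 days (on this read-out lower numbers stand for stronger inhibition and higher numbers for weaker inhibition), compound 1 (`COc1cc(NC(C)CCCNC(=O)NNC(=O)NCCCCCO)c2ncccc2c1`) gives 4000 nM. Compound 2 (`COc1ccc(/C(=N/NC(=O)NCCCC(C)Nc2cc(OC)cc3cccnc23)c2ccccc2)cc1`) gives 5000 nM, and compound 3 (`COc1cc(NC(C)CCCNC(=O)NNC(=O)N(C)C(c2ccccc2)c2ccccc2)c2ncccc2c1`) gives 5000 nM. All three values lie within the usual scatter of repeated measurements, so compound 1 stands level with the other two, although the three structures end in quite different groups.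

Compound 4 (`COc1cc(NC(C)CCCNC(=O)NNC(=O)NC(CO)(CO)CO)c2ncccc2c1`) differs from compound 1 in one place: 2-hydroxy-1,1-bis(hydroxymethyl)ethyl stands in place of 5-hydroxypentyl on an amide-type nitrogen (2-hydroxy-1,1-bis(hydroxymethyl)ethyl in place of 5-hydroxypentyl on an amide-type nitrogen). Among the compounds with values here, no two measured compounds differ in only one place, so the data give no direct measure of a swap like this one.

With compound 2 at 5000 nM and compound 3 at 5000 nM, both close to compound 1, a large step is not expected. A small move towards weaker inhibition, perhaps no larger than the scatter, is expected and estimated as a 1.8-fold higher number from compound 1 to compound 4 (0.24 log units; within the scatter). The expected value for compound 4 is 7000 nM, with an estimated range from 2500 nM to 20000 nM.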

Compound 4, half-maximal inhibitory concentration: 28000 nM
Compound 4: the middle estimate sits 4.0-fold (0.60 log units) below what was measured; measured number outside the range, above it.
By their numbers in this assay, from the lowest: compounds 1, 2 and 3 (each within the scatter of the next); then compound 4.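

In this assay, the group on this amide-type nitrogen does affect the read-out: 2-hydroxy-1,1-bis(hydroxymethyl)ethyl in place of 5-hydroxypentyl gives a 7.0-fold higher number from compound 1 to compound 4 (0.85 log units; beyond the scatter), a step beyond the scatter towards weaker inhibition. Within the data shown here, this is the first step that can be read directly, as the earlier compounds offered no pair differing in one place. The group that enters has 3 hydrogen-bond donors and 3 hydrogen-bond acceptors, against 1 of each in the group that leaves, but nothing measured here explains why the number rises.

This one swap changes the chain's shape and its number of hydroxyl groups together, so the contribution of each remains unresolved. Also open, as far as these compounds go, is how an unbranched chain ending in an amine or a carboxylic acid would compare at this nitrogen.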